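Replacing Fluoro in Compound 1 with an Amino Ester

This account rests on a few compounds, and the source may have more. Where it says the series, first, only, none or still open, it means among the compounds named here.

Measured in a functional assay on K562 cells (Homo sapiens) for cytotoxicity, read by trypan blue exclusion, with a stated time of 96 h; a higher number here means a weaker inhibitor, a lower number a stronger inhibitor:
- compound 1 `COc1cc(OC)c(/C=C/S(=O)(=O)Nc2ccc(OC)c(F)c2)c(OC)c1` gives 75 nM
- compound 2 `COc1ccc(NS(=O)(=O)/C=C/c2c(OC)cc(OCCCC(=O)O)cc2OC)cc1N` gives 10000 nM

Of these two numbers, compound 1 holds the lower (75 nM) and compound 2 the higher (10000 nM), a gap well beyond the scatter. The account now follows compound 3 `COC(=O)C(C)(C)Nc1cc(NS(=O)(=O)/C=C/c2c(OC)cc(OC)cc2OC)ccc1OC`, which has not yet been measured in this assay and departs from compound 1 in one place. It has (1-(methoxycarbonyl)-1-methylethyl)amino in place of fluoro on an aromatic carbon, ortho to a methoxy group ((1-(methoxycarbonyl)-1-methylethyl)amino in place of fluoro on an aromatic carbon). For the measured compounds named here, no measured pair differs in only one place, so the data offer no direct guide to the size of this step. A move towards a higher number is expected, beyond the scatter but uncertain in size, with compound 1 at 75 nM as the starting point and a far larger group entering than the one that leaves. The expected change is a 4.0-fold higher number from compound 1 to compound 3 (0.60 log units; beyond the scatter) in the estimate made here. For compound 3 the estimated value is 300 nM with an expected range from 40 nM to 3000 nM in this assay.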

Compound 3, half-maximal inhibitory concentration: 300 nM
Beside the measured number, compound 3's estimate shows no gap at the digits printed; the range from low to high includes it.
By their numbers in this assay, from the lowest: compound 1; then compound 3; then compound 2.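

In this assay, for the compounds shown here, the exchange of fluoro for (1-(methoxycarbonyl)-1-methylethyl)amino gives a 4.0-fold higher number from compound 1 to compound 3 (0.60 log units; beyond the scatter), the first reading of a change made in one place, here on an aromatic carbon ortho to a methoxy group. The step is modest for so large a change in the substituent, from 1 heavy atom to 8 heavy atoms with a hydrogen-bond donor added, and compound 3 keeps a value of 300 nM, so this position accepts a much larger group without the activity being lost. No measurement is at hand that explains the size of this step.

From the compounds shown here alone, a single step cannot show which part of the entering group sets its size, so it remains open how a plain amino group, the free carboxylic acid in place of the methyl ester, or a longer chain without the two methyl groups would stand at this carbon. Going by these compounds, it also remains open whether the same exchange would give a similar step with other groups elsewhere on the core of compound 1.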